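Benzyl in place of methyl on the ring nitrogen

This account rests on a few compounds, and the source may have more. Where it says the series, first, only, none or still open, it means among the compounds named here.

Measured so far:
compound 1 `O=C1CNc2nc(Nc3ccc(Cl)cc3)ncc2N1` gives 41700 nM in a functional assay on MDA-MB-231 cells (Homo sapiens) for cytotoxicity, read by MTT assay, with a stated time of 48 h; on this read-out higher numbers stand for weaker inhibition and lower numbers for stronger inhibition
compound 2 `CN1CC(=O)Nc2cnc(Nc3ccc(Cl)cc3)nc21` gives > 100000 nM in this assay; this is a limit, not a number

Compound 2 stands at the limit of the assay, which is where the limit of > 100000 nM in this assay, at which 1 of the 2 values shown sits, places it, so its true value is not known and any step from it can only be bounded. The change to compound 3 `O=C1CN(Cc2ccccc2)c2nc(Nc3ccc(Cl)cc3)ncc2N1` is phenyl in place of hydrogen on a saturated chain carbon bound to a nitrogen on an aromatic ring in a ring. Among the compounds with values here, only one measured step touches the same nitrogen on an aromatic ring in a ring, namely an at least 2.3-fold higher number from compound 1 to compound 2 (0.37 log units; beyond the scatter), which went toward weaker inhibition. Within the data shown here, nothing measured tells how a larger group on that same carbon behaves, so the sole guide is that substitution there has not helped. No step beyond the scatter is therefore expected, with the estimate a number no higher from compound 2 to compound 3 (the limit leaves the size open), and a limit rather than a number remains the most likely read-out. Compound 3 is expected at 100000 nM, within 30000 nM to 300000 nM.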

Compound 3, half-maximal inhibitory concentration: > 100000 nM
Compound 3 was reported as a limit; the forecaster's own chance of this, stated with the estimate: 60%; the middle value lies on the limit itself.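

In this assay compound 3 gives > 100000 nM, which is a limit and not a number. The step between compound 2 and compound 3 cannot be read, as both values are limits, so methyl and benzyl cannot be ranked against each other. What the new compound adds is that the larger benzyl group on this ring nitrogen, with its six-membered aromatic ring, also gives an at least 2.3-fold higher number from compound 1 to compound 3 (0.37 log units; beyond the scatter), so both substituents shown on this nitrogen lie on the weaker side of hydrogen.

How far compound 2 and compound 3 each lie past the measurable range stays open, with both sitting at one value: the limit of > 100000 nM in this assay, at which 2 of the 3 values shown sit.

Also open, going by these compounds, is whether a substituent of another kind on this nitrogen, such as a longer chain ending in an amine or a carboxylic acid, would behave like methyl and benzyl.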